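The source may report more compounds than this note shows. Statements on the series, on what has been measured and on what is new or still open speak of the compounds shown alone.

Measured compounds:
compound 1, `CNCc1c(OC)cc(Oc2cccc(Nc3ccccc3)c2)cc1OC`, 8930 nM
compound 2, `COc1cc(Oc2cccc(Nc3ccccc3)c2)cc(OC)c1CNCc1ccc(C)cc1`, 5400 nM
compound 3, `COc1cc(Oc2cccc(Nc3ccccc3)c2)cc(OC)c1CNC(C)C`, > 20000 nM

In a functional assay on HCT-15 cells (Homo sapiens) for inhibition, read by MTT assay, with a stated time of 72 h (on this read-out higher numbers stand for weaker inhibition and lower numbers for stronger inhibition), compound 1 gives 8930 nM and compound 2 gives 5400 nM. For compound 3 only a limit is known, (the limit of > 20000 nM in this assay, at which 1 of the 3 values shown sits), so its number is not pinned down. Compound 4, `COc1cc(Oc2cccc(Nc3ccccc3)c2)cc(OC)c1CNCc1ccc(Br)cc1`, differs from compound 3 in one place: 4-bromobenzyl in place of isopropyl on an amine nitrogen. Among the measured compounds shown here, two measured steps bear on this change. The step of an at least 3.7-fold higher number from compound 2 to compound 3 (0.56 log units; beyond the scatter) runs in the opposite direction, and so does an at least 2.2-fold higher number from compound 1 to compound 3 (0.35 log units; beyond the scatter). Compound 4 carries a 4-bromobenzyl much like the 4-methylbenzyl of compound 2, so the reverse step of an at least 3.6-fold lower number from compound 3 to compound 4 (0.56 log units; beyond the scatter) is expected, toward a lower number. Compound 4 is therefore estimated at 5500 nM, with a range from 2500 nM to 14000 nM.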

Compound 4, half-maximal inhibitory concentration: 5410 nM
Beside the measured number, compound 4's estimate is 1.0-fold (0.01 log units) above it; the measured number falls inside the stated range.
By their numbers in this assay, from the lowest: compounds 2, 4 and 1 (each within the scatter of the next). At a limit, above all of these: compound 3.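

In this assay, 4-bromobenzyl in place of isopropyl on the amine nitrogen gives an at least 3.6-fold lower number from compound 3 to compound 4 (0.56 log units; beyond the scatter), though compound 3 is known only as a limit: the limit of > 20000 nM in this assay, at which 1 of the 4 values shown sits.

Bromo in place of methyl gives a 1.0-fold higher number from compound 2 to compound 4 (0.00 log units; within the scatter), so these two groups cannot be told apart here. Compound 1, with only a methyl on that nitrogen, cannot be separated from compound 4 either, with a 1.7-fold lower number from compound 1 to compound 4 (0.22 log units; within the scatter), so the benzyl groups show an edge over isopropyl but not over methyl.

Open, as far as these compounds go, is whether a plain benzyl or a 4-methoxybenzyl would sit with compounds 2 and 4, and whether an ethyl on the nitrogen would sit with compound 1 or compound 3.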